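This account rests on a few compounds, and the source may have more. Where it says the series, first, only, none or still open, it means among the compounds named here.

Compound 1 `C=CCNC(=O)[C@@H](NC(=O)[C@@](O)(CCCN(Cc1ccc(Br)cc1)NC(=O)[C@@H](NC(=O)OC)C(C)(C)C)Cc1ccc(Br)cc1)C(C)C` is the reference point here. Going by the values given here, in an ADME assay on MT4 cells (Homo sapiens) for cytotoxicity, read by XTT assay, with a stated time of 5 days (on this read-out higher numbers stand for lower toxicity in this test and lower numbers for higher toxicity in this test), compound 1 gives 22000 nM, the highest of the three numbers measured so far. Compound 2 `C=CCNC(=O)[C@@H](NC(=O)[C@](O)(CCCN(Cc1ccc(Br)cc1)NC(=O)[C@@H](NC(=O)OC)C(C)(C)C)Cc1ccc(Br)cc1)C(C)C` has the same atoms and bonds and differs only in configuration as drawn; in this assay compound 2 gives 4500 nM, and the step of a 4.9-fold lower number from compound 1 to compound 2 (0.69 log units; beyond the scatter) rests on nothing more than the fact that compounds 1 and 2 differ only in the configuration as drawn. Compound 3 `C=CCNC(=O)[C@@H](NC(=O)[C@](O)(CCCN(Cc1ccc(Br)cc1)NC(=O)[C@@H](NC(=O)OC)C(C)(C)C)Cc1ccc(C=C)cc1)C(C)C` carries vinyl in place of bromo on an aromatic carbon; in this assay compound 3 gives 5800 nM, so the step of a 1.3-fold higher number from compound 2 to compound 3 (0.11 log units; within the scatter) stays within the scatter.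

Compound 4 `C=CCNC(=O)[C@@H](NC(=O)[C@@](O)(CCCN(Cc1ccc(Br)cc1)NC(=O)[C@@H](NC(=O)OC)C(C)(C)C)Cc1ccc(CC=C)cc1)C(C)C` has not yet been measured. It differs from compound 1 by allyl in place of bromo on an aromatic carbon. The stereo step from compound 1 to compound 2 has no bearing on this change. Among the compounds with values here, the one step that does, a 1.3-fold higher number from compound 2 to compound 3 (0.11 log units; within the scatter), replaced bromo with a related unsaturated group and moved little, so no step beyond the scatter is expected here in either direction. Compound 4 is therefore expected to give about 22000 nM in this assay, with a range from 9000 nM to 50000 nM. That amounts to an expected step of no change at the digits printed from compound 1 to compound 4 (within the scatter).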

Compound 4, half-maximal cytotoxic concentration: 24000 nM
Compound 4: the middle estimate sits 1.1-fold (0.04 log units) below what was measured; the range from low to high includes it.
By their numbers in this assay, from the lowest: compounds 2 and 3 (each within the scatter of the next); then compounds 1 and 4 (each within the scatter of the next).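

In this assay, the step of a 1.1-fold higher number from compound 1 to compound 4 (0.04 log units; within the scatter) stays within the scatter, so this position on the aromatic ring takes allyl, with its 3 heavy atoms, in place of the single bromine without a readable change in the number. The earlier vinyl step, a 1.3-fold higher number from compound 2 to compound 3 (0.11 log units; within the scatter), came from the other drawn configuration at the chain carbon, so the same lack of a readable change now appears with a larger unsaturated group and in the configuration of compound 1. Nothing available explains why this change leaves the number in place.

The compounds shown leave open whether an amine or a carboxylic acid at this position would hold the number as well. They also do not show whether a longer chain would, or what allyl does in the configuration of compound 2.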